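Varying the amide cap in a shared series

A few compounds are considered here, and "the series" means these few. Any claim that something is new, unique, unknown or untested is made for them only; others in the source may bear on it.

Measured so far in an assay for inhibition of histone deacetylase 8 (Homo sapiens), read by fluorescence, with stated times of 15 min and 60 min; on this read-out lower numbers stand for stronger inhibition and higher numbers for weaker inhibition:
compound 1 `Nc1cc(O)ccc1NC(=O)c1ccc(CNc2nccc(-c3cccnc3)n2)cc1` — > 20000 nM
compound 2 `Nc1cc2ccccc2cc1NC(=O)c1ccc(CNc2nccc(-c3cccnc3)n2)cc1` — > 20000 nM

In this assay compound 1 gives > 20000 nM, which is a limit of the assay and not a number. Compound 2 gives > 20000 nM in this assay, again a limit. The change between them, a step that the two limits leave unreadable from compound 1 to compound 2, is of unreadable size because both values sit at the limit of > 20000 nM in this assay, at which 2 of the 2 values shown sit. Compound 2 therefore stands at the limit, and nothing places it above or below compound 1.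

Compound 3 `Nc1cc(C(=O)O)ccc1NC(=O)c1ccc(CNc2nccc(-c3cccnc3)n2)cc1` differs from compound 2 by a group of 10 heavy atoms (7 carbon, 1 nitrogen, 2 oxygen; one six-membered aromatic ring of carbon only) in place of a group of 11 heavy atoms (10 carbon, 1 nitrogen; 2 six-membered aromatic rings of carbon only), on an amide-type nitrogen. For the measured compounds named here, the one measured step that bears on an exchange at this nitrogen is the step already described, and its size cannot be read. No information in the series points to a gain or loss beyond the scatter in this assay. The estimate for compound 3 is 20000 nM, with a range from 5000 nM to 60000 nM. This estimate means a step of a number no higher from compound 2 to compound 3 (the limit leaves the size open), with a high chance that the assay again reports only a limit.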

Compound 3, half-maximal inhibitory concentration: > 20000 nM
Compound 3 gave a limit, no number (the forecaster's own chance of this, stated with the estimate: 75%); the middle value lies on the limit itself.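

For the compounds shown here, no step among compound 1, compound 2 and compound 3 can be read in this assay, because each value is a limit of the assay and not a number: the limit of > 20000 nM in this assay, at which 3 of the 3 values shown sit.
The compounds shown leave open whether any amide cap on the shared core gives measurable inhibition, and how far these three compounds lie from one another.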